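A few compounds are considered here, and "the series" means these few. Any claim that something is new, unique, unknown or untested is made for them only; others in the source may bear on it.

In an ADME assay on L929 cells (Mus musculus) for cytotoxicity, with a stated time of 72 h (on this read-out lower numbers stand for stronger inhibition and higher numbers for weaker inhibition), compound 1 (`CC(=O)C(C)Oc1ccc2c(c1)B(O)OC2`) gives > 10 ug/mL, a limit of the assay and not a number. Compound 2 (`CCC(Oc1ccc2c(c1)B(O)OC2)C(C)=O`) gives > 10 ug/mL, which is also a limit, so its position is known only from that limit. Both compounds therefore sit at one reading: the limit of > 10 ug/mL in this assay, at which 2 of the 2 values shown sit. Among the measured compounds shown here, the only measured step is a step that the two limits leave unreadable from compound 1 to compound 2, with methyl in place of hydrogen on a saturated chain carbon. Compound 3 (`CC(=O)C(Oc1ccc2c(c1)B(O)OC2)C(C)C`) differs from compound 2 by methyl in place of hydrogen on a saturated chain carbon bound to two saturated chain carbons, the same difference read as ethyl to isopropyl. For the measured compounds named here, the one measured step offers no size to carry over, so no shift beyond the scatter is expected in this assay. The expected step is a step that the limit leaves unreadable from compound 2 to compound 3, an estimate that points in no firm direction. The estimated value for compound 3 is 20 ug/mL, with an expected range from 10 ug/mL to 60 ug/mL.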

Compound 3, half-maximal inhibitory concentration: > 10 ug/mL
Compound 3 was reported as a limit (the forecaster's own chance of this, stated with the estimate: 85%); the middle value is on the limit's open side.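

Among the compounds shown here, no step among compound 1, compound 2 and compound 3 can be read in this assay, and all three share one reading: the limit of > 10 ug/mL in this assay, at which 3 of the 3 values shown sit. The compounds shown leave open how far past that limit each one lies, and whether the larger chain groups shift the value at all.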